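Methyl for trifluoromethyl on the shared core

The source may report more compounds than this note shows. Statements on the series, on what has been measured and on what is new or still open speak of the compounds shown alone.

Compound 3 `CN(C(=O)NC(=O)c1c(F)cccc1F)c1nc(C(F)(F)F)c(C(=O)N/N=C/c2cc(C(F)(F)F)cc(C(F)(F)F)c2)s1` gives 6.85 ug/mL in a functional assay on MCF7 cells (Homo sapiens) for inhibition, read by MTT assay, with a stated time of 72 h; on this read-out lower numbers stand for stronger inhibition and higher numbers for weaker inhibition. Compound 1 `Cc1nc(N(C)C(=O)NC(=O)c2c(F)cccc2F)sc1C(=O)N/N=C/c1cc(C(F)(F)F)cc(C(F)(F)F)c1` differs from it by methyl in place of trifluoromethyl on an aromatic carbon and gives 11.6 ug/mL; the step is a 1.7-fold higher number from compound 3 to compound 1 (0.23 log units; within the scatter). Compound 2 `CN(C(=O)NC(=O)c1c(F)cccc1F)c1nc(C(F)(F)F)c(C(=O)N/N=C/c2ccc(C(F)(F)F)cc2)s1` gives 35.3 ug/mL in this assay; how its core differs from that of compound 3 is not broken down here, and its values stand apart from both. Compound 4 `Cc1nc(N(C)C(=O)NC(=O)c2c(F)cccc2F)sc1C(=O)N/N=C/c1ccc(C(F)(F)F)cc1` differs from compound 2 by methyl in place of trifluoromethyl on an aromatic carbon, the same change as between compound 3 and compound 1. Going by the values given here, the step is expected to be a 1.4-fold higher number from compound 2 to compound 4 (0.15 log units; within the scatter), resting on the single earlier measured step of a 1.7-fold higher number from compound 3 to compound 1 (0.23 log units; within the scatter), which is within the scatter. Compound 4 is therefore estimated at 50 ug/mL in this assay, with a plausible range from 25 ug/mL to 100 ug/mL.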

Compound 4, half-maximal inhibitory concentration: 30.6 ug/mL
The estimate for compound 4 lay 1.6-fold (0.21 log units) above the measured number; measured number inside the range.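

In this assay, methyl in place of trifluoromethyl on the core of compound 2 gives a 1.2-fold lower number from compound 2 to compound 4 (0.06 log units; within the scatter). Set beside the earlier step, the two cores show no difference in how the change reads: the same change on two cores in this assay, a 1.7-fold higher number (0.23 log units; within the scatter) from compound 3 to compound 1 and a 1.2-fold lower number (0.06 log units; within the scatter) from compound 2 to compound 4, 2.0-fold (0.29 log units) apart, within the scatter of two such steps

On these two cores the change therefore carries over as a step that stays within the scatter, but two pairs do not show that it would do so on other cores, and the opposite signs of the two steps carry no meaning at this size.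

The compounds shown leave open what other groups at this place on the ring would give, such as an ethyl, an amine or a carboxylic acid.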